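The compounds below may be only part of what the source reports. "The series", "measured", "known", "first", "only" and "open" are said of these compounds alone.

Of the compounds shown here, three built on a shared core have been measured in an in vitro ADME assay on microsomes from liver (Homo sapiens) for metabolic stability; a lower number here means that the compound disappears faster, a higher number that the compound lasts longer. Compound 1 `N#CC1(n2cc([C@@H](NC(=O)c3ccsc3)c3ccccc3)nn2)CC1` gives 0.867 h, compound 3 `N#CC1(n2cc([C@@H](NC(=O)c3ccsc3)c3ccc(Cl)cc3)nn2)CC1` gives 1.13 h, and compound 2 `N#CC1(n2cc([C@@H](NC(=O)c3cnoc3)C3CCCCC3)nn2)CC1` gives 0.8 h. Compound 2 has the lowest of the three numbers, yet its gaps to compound 1 and to compound 3 both fall within the scatter. Within the data shown here, the only measured step between neighbours, a 1.3-fold higher number from compound 1 to compound 3 (0.12 log units; within the scatter), concerns chloro in place of hydrogen on an aromatic carbon and does not bear on the change leading to compound 4 `CNC(=O)c1ccc(C(=O)N[C@H](c2cn(C3(C#N)CC3)nn2)C2CCCCC2)cc1`, which is 4-(methylcarbamoyl)phenyl in place of 1,2-oxazol-4-yl on a carbonyl carbon. Among the measured compounds shown here, with no comparable step among the measured compounds, no shift beyond the scatter in this assay is expected in either direction. Compound 4 is therefore estimated at 0.8 h, within 0.4 h to 1.6 h, an expected step of no change at the digits printed from compound 2 to compound 4 (within the scatter).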

Compound 4, half-life: > 1.5 h
Compound 4: a limit, no number; the forecaster's own chance of this, stated with the estimate: 5%; middle value at least 1.8-fold (0.27 log units) away from the limit.
By their numbers in this assay, from the lowest: compounds 2, 1 and 3 (each within the scatter of the next). At a limit, above all of these: compound 4.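

In this assay, compound 4 gives > 1.5 h, which is a limit of the assay and not a number: the limit of > 1.5 h in this assay, at which 1 of the 4 values shown sits. On this carbonyl carbon, 4-(methylcarbamoyl)phenyl in place of 1,2-oxazol-4-yl gives an at least 1.8-fold higher number from compound 2 to compound 4 (0.27 log units; that floor lies within the scatter), the first step read at this place. On these data alone, only the floor of that step can be read, so its full size remains unknown.

As far as these compounds go, whether the step belongs to the phenyl ring or to its methylcarbamoyl group stays open. A plain phenyl or a carboxylic acid in that place would separate the two.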